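A few compounds are considered here, and "the series" means these few. Any claim that something is new, unique, unknown or untested is made for them only; others in the source may bear on it.

Measured so far in a functional assay on HeLa cells (Homo sapiens) for antiproliferative activity, read by MTT assay, with a stated time of 48 h; a higher number here means a weaker inhibitor, a lower number a stronger inhibitor
- compound 1 `COc1cccc2c1Oc1cc(O)c(O)cc1CCc1ccc(O)c(c1)Oc1ccc(cc1)CC2` gives 2610 nM
- compound 2 `Oc1ccc2cc1Oc1ccc(cc1)CCc1cccc(O)c1Oc1ccc(cc1)CC2` gives 10500 nM
- compound 3 `Oc1ccc2cc1Oc1ccc(cc1)CCc1ccc(O)c(c1)Oc1cccc(c1)CC2` gives 11700 nM

Compound 3 thus sits within the scatter of compound 2 and beyond the scatter above compound 1. Compound 4 (`Oc1ccc2cc1Oc1cccc(c1)CCc1ccc(O)c(c1)Oc1ccc(cc1O)CC2`) differs from compound 3 by hydroxy in place of hydrogen on an aromatic carbon. Within the data shown here, no measured pair shows this change alone. Among the measured compounds shown here, compound 1 (2610 nM) holds the only clearly lower number, but it differs from compound 3 in more than one place, so it offers only weak guidance. A small fall in the number is expected, and the estimated step (a 1.8-fold lower number from compound 3 to compound 4 (0.26 log units; within the scatter)) may stay within the scatter. The estimate for compound 4 is 6500 nM with an expected range from 2500 nM to 15000 nM in this assay when it is measured.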

Compound 4, half-maximal inhibitory concentration: 19500 nM
Compound 4: middle estimate off by 3.0-fold (0.48 log units), on the low side; the measured number lies above the stated range.
By their numbers in this assay, from the lowest: compound 1; then compounds 2, 3 and 4 (each within the scatter of the next).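

Among these compounds, the swap of hydroxy in place of hydrogen on an aromatic carbon, ortho to a fused ring and meta to a fused ring, gives a 1.7-fold higher number from compound 3 to compound 4 (0.22 log units; within the scatter) in this assay, the first comparison here of compounds that differ in one place. At this position, the added hydroxy therefore leaves the two compounds indistinguishable in this assay. No evidence at hand bears on this result. Going by these compounds, whether an amine or a carboxylic acid on the same aromatic carbon would take the number beyond the scatter remains open, as does whether hydroxy would give the same result on another aromatic carbon of the shared core.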